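This account rests on a few compounds, and the source may have more. Where it says the series, first, only, none or still open, it means among the compounds named here.

Working notes on the series. One shared core runs through all compounds, and the variation sits on a single aromatic carbon of the six-membered ring with one nitrogen. Compound 1 `CC(C)(C)c1ccc(NC(=O)c2ccc(-c3ccccn3)cc2)cc1` carries hydrogen there; in a functional assay for antagonist activity at transient receptor potential cation channel subfamily V member 1 (Rattus norvegicus) (on this read-out higher numbers stand for weaker inhibition and lower numbers for stronger inhibition), compound 1 gives 8 nM. Compound 2 `CN(C)Cc1cccnc1-c1ccc(C(=O)Nc2ccc(C(C)(C)C)cc2)cc1` carries (dimethylamino)methyl at that carbon, and compound 2 gives 234 nM. Compound 3 `Cc1nnc(-c2cccnc2-c2ccc(C(=O)Nc3ccc(C(C)(C)C)cc3)cc2)o1` carries 5-methyl-1,3,4-oxadiazol-2-yl, and compound 3 gives 34 nM, the second highest of the three numbers: a 4.3-fold higher number from compound 1 to compound 3 (0.63 log units; beyond the scatter), while a 6.9-fold lower number from compound 2 to compound 3 (0.84 log units; beyond the scatter). The third step, a 29-fold higher number from compound 1 to compound 2 (1.47 log units; beyond the scatter), completes the picture: every group placed on this carbon has so far raised the number, the oxadiazole by less than the aminomethyl group.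

Compound 4 `CC(C)(C)c1ccc(NC(=O)c2ccc(-c3ncccc3-c3nn[nH]n3)cc2)cc1` differs from compound 3 in one place: 2H-tetrazol-5-yl in place of 5-methyl-1,3,4-oxadiazol-2-yl on an aromatic carbon. The two steps from compound 1 bear on it, as both set a group onto the same carbon, and both went upward. Among the compounds with values here, no measured compound carries a hydrogen-bond donor at this position, so the size of the step is uncertain. For compound 4 a moderate rise is expected, a 2.9-fold higher number from compound 3 to compound 4 (0.47 log units; beyond the scatter), and the estimate for compound 4 is 100 nM, with a range from 25 nM to 400 nM.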

Compound 4, half-maximal inhibitory concentration: > 4000 nM
Compound 4: a limit, no number; the forecaster's own chance of this, stated with the estimate: 10%; middle value at least 40-fold (1.60 log units) from the limit.
By their numbers in this assay, from the lowest: compound 1; then compound 3; then compound 2. At a limit, above all of these: compound 4.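

In this assay compound 4 gives > 4000 nM, which is a limit of the assay and not a number. This carbon therefore separates two five-membered aromatic rings sharply, with an at least 110-fold higher number from compound 3 to compound 4 (2.07 log units; beyond the scatter), so a ring-for-ring exchange here can matter far more than the earlier oxadiazole step suggested. Within the data shown here, the (dimethylamino)methyl group also no longer marks the top of the series, with an at least 17-fold higher number from compound 2 to compound 4 (1.23 log units; beyond the scatter) and an at least 500-fold higher number from compound 1 to compound 4 (2.69 log units; beyond the scatter), and the 2H-tetrazol-5-yl group is the only group here that counts a hydrogen-bond donor.

On these data alone, the true size of these steps stays open, as does whether the donor count or some other difference between the two rings goes with the loss. A carboxylic acid or a tetrazole with a methyl on nitrogen at this carbon would bear on that question.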